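The compounds below may be only part of what the source reports. "The series", "measured", "known", "first", "only" and "open" are said of these compounds alone.

Measured compounds:
Compound 1, `NC(=O)Cn1ccc2cc(-c3ccc4oc(NC5CCCCC5)nc4c3)ccc21`, in an assay on HEK293 cells for inhibition of Fatty-acid amide hydrolase 1 (Homo sapiens), read by fluorescence; on this read-out lower numbers stand for stronger inhibition and higher numbers for weaker inhibition: 214 nM
Compound 2, `CN(c1ccccc1)c1nc2cc(-c3ccc4c(ccn4C)c3)ccc2o1`, in this assay: 68 nM

The study so far covers two compounds. Compound 2 stands at the lowest number of the two, and its nearest neighbour, compound 1, lies at a higher number, a gap that falls beyond the usual scatter of this assay. Going by the values given here, no pair of measured compounds differing in a single place is available, so no measured step can be drawn on.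

Compound 3, `C[C@@H]1CN(c2nc3cc(-c4ccc5c(ccn5C)c4)ccc3o2)C[C@H](C)O1`, is not yet measured. It differs from compound 2 in one place: 2,6-dimethylmorpholin-4-yl in place of methyl(phenyl)amino on an aromatic carbon. The replacing group keeps the same count of heavy atoms but exchanges the aromatic ring of carbon only for a saturated ring carrying two hetero atoms and two defined stereocentres.

Among the compounds with values here, with no measured step to lean on, the expectation for compound 3 rests only on the two values above. Compound 1, whose group on that same carbon is also a non-aromatic amine, sits at the weaker end, so a move toward weaker inhibition is expected, of a size beyond the scatter, a 2.4-fold higher number from compound 2 to compound 3 (0.37 log units; beyond the scatter). The estimate for compound 3 is 160 nM, in the range 45 nM to 550 nM.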

Compound 3, half-maximal inhibitory concentration: 168 nM
For compound 3 the middle estimate is 1.1-fold (0.02 log units) below the measured one; the measured number falls inside the stated range.
By their numbers in this assay, from the lowest: compound 2; then compounds 3 and 1 (each within the scatter of the next).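

Going by these compounds alone, this is the first measured step at the aromatic carbon of the five-membered ring with 1 nitrogen and 1 oxygen: in this assay, replacing methyl(phenyl)amino with 2,6-dimethylmorpholin-4-yl gives a 2.5-fold higher number from compound 2 to compound 3 (0.39 log units; beyond the scatter), a modest weakening. It shows that on this shared core, with the heavy-atom count of the group unchanged, a saturated ring with 2 hetero atoms can take the place of the group with the aromatic ring of carbon only, at some cost in inhibition but with inhibition retained. The data offered here give no measured reason for the size or direction of this step.

Which part of the change carries the step stays open: the loss of the aromatic ring, the ring oxygen, the two methyl groups or the two defined stereocentres could each contribute, and unsubstituted morpholin-4-yl, piperidin-1-yl or benzylamino at this carbon would help separate them. Also open, from the compounds shown here alone, is whether the step would hold with the rest of the molecule changed, for instance with the acetamide group that compound 1 carries in place of the methyl group on the ring nitrogen.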